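Working notes: amide versus methylsulfonyl on the piperidine nitrogen

The compounds below may be only part of what the source reports. "The series", "measured", "known", "first", "only" and "open" are said of these compounds alone.

Measured so far in an ADME assay on Caco-2 cells (Homo sapiens) for permeability, in the apical to basolateral direction; on this read-out higher numbers stand for higher permeability and lower numbers for lower permeability:
- compound 1, `Cn1cncc1CN1CC(N(Cc2cccc(-n3cccc3)c2)S(=O)(=O)c2ccccn2)Cc2cc(C#N)ccc21`: 2.3 10^-6 cm/s
- compound 2, `Cn1cncc1CN1CC(N(CC2CCN(C(=O)C3CC3)CC2)S(=O)(=O)c2ccccn2)Cc2cc(C#N)ccc21`: 0.5 10^-6 cm/s
- compound 3, `Cn1cncc1CN1CC(N(CC2CCN(S(C)(=O)=O)CC2)S(=O)(=O)c2ccccn2)Cc2cc(C#N)ccc21`: 0.1 10^-6 cm/s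

Compound 3 stands lowest of the three, with a 5.0-fold lower number from compound 2 to compound 3 (0.70 log units; beyond the scatter) and a 23-fold lower number from compound 1 to compound 3 (1.36 log units; beyond the scatter); the other measured step is a 4.6-fold lower number from compound 1 to compound 2 (0.66 log units; beyond the scatter).

Compound 4 `CC(C)C(=O)N1CCC(CN(C2Cc3cc(C#N)ccc3N(Cc3cncn3C)C2)S(=O)(=O)c2ccccn2)CC1` differs from compound 3 by isopropylcarbonyl in place of methylsulfonyl on an amine nitrogen in a ring. The step that bears on it directly is a 5.0-fold lower number from compound 2 to compound 3 (0.70 log units; beyond the scatter), which separates a cyclopropylcarbonyl from a methylsulfonyl on the same ring nitrogen; compound 4 reverses that exchange with a closely related isopropylcarbonyl. A modest rise in this assay is therefore expected, about a 5.0-fold higher number from compound 3 to compound 4 (0.70 log units; beyond the scatter). For compound 4 the permeability is estimated at 0.5 10^-6 cm/s, with a range of 0.2 10^-6 cm/s to 1.2 10^-6 cm/s.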

Compound 4, apparent permeability: 0.5 10^-6 cm/s
The estimate for compound 4 equals the measured number at the digits printed, and the stated range covers the measured number.
By their numbers in this assay, from the lowest: compound 3; then compounds 2 and 4 (each within the scatter of the next); then compound 1.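

In this assay, a second carbonyl group on this ring nitrogen again stands above methylsulfonyl, with a 5.0-fold higher number from compound 3 to compound 4 (0.70 log units; beyond the scatter), so the earlier gap does not rest on cyclopropylcarbonyl alone. Isopropyl in place of cyclopropyl on the carbonyl carbon gives no change at the digits printed from compound 2 to compound 4 (within the scatter), while the piperidine side chain still gives a 4.6-fold lower number from compound 1 to compound 4 (0.66 log units; beyond the scatter). No measured evidence available here accounts for these differences. As far as these compounds go, how an acetyl group or a urea on the same ring nitrogen would read in this assay remains open, as does whether any group at this nitrogen can close the gap to compound 1.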